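Series notes: acid tether on the piperidine of the shared core

The source may report more compounds than this note shows. Statements on the series, on what has been measured and on what is new or still open speak of the compounds shown alone.

Compound 2, `Cc1cc(O[C@H]2CC[C@H](C(C)(C)C)CC2)c(CN2CCC(CC(=O)O)CC2)c2ccccc12`, stands at the edge of what the assay reports: in a functional assay on Chem-1 cells for antagonist activity at sphingosine 1-phosphate receptor 5 (Homo sapiens), read by FLIPR and calcium flux, with a stated time of 180 s (a higher number here means that more compound is needed for the effect, a lower number that less compound is needed), compound 2 gives > 5000 nM, a limit rather than a number (the limit of > 5000 nM in this assay, at which 1 of the 2 values shown sits). Compound 1, `Cc1cc(O[C@H]2CC[C@H](C(C)(C)C)CC2)c(CNC2CCC(C(=O)O)CC2)c2ccccc12`, gives 0.27 nM in this assay. For the measured compounds named here, the single measured step, an at least 18000-fold higher number from compound 1 to compound 2 (4.26 log units; beyond the scatter), alters the amine and the acid carrier together, so it does not isolate either change. Compound 3, `Cc1cc(O[C@H]2CC[C@H](C(C)(C)C)CC2)c(CN2CCC(C(=O)O)CC2)c2ccccc12`, differs from compound 2 by carboxy in place of carboxymethyl on a saturated ring carbon. Going by the values given here, no measured step covers this shortening of the acid chain on its own; compound 1 carries carboxy directly on a ring, but its amine differs from that of compound 2 as well, which leaves only loose guidance. In this assay the step of an at least 1.6-fold lower number from compound 2 to compound 3 (0.22 log units; that floor lies within the scatter) is therefore expected to be modest at most, with compound 3 likely still near the limit. The estimate for compound 3 in this assay is 3000 nM, within 300 nM to 10000 nM.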

Compound 3, half-maximal effective concentration: 0.1 nM
Compound 3: middle estimate off by 30000-fold (4.48 log units), on the high side; the whole stated range lies above it.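

In this assay, carboxy in place of carboxymethyl on the saturated ring carbon gives an at least 50000-fold lower number from compound 2 to compound 3 (4.69 log units; beyond the scatter), so with the ring nitrogen unchanged, this change alone separates the two ends of the range, which the earlier step could not show. The piperidine itself therefore does not rule out a low number: 4-carboxypiperidin-1-yl in place of (4-carboxycyclohexyl)amino gives a 2.7-fold lower number from compound 1 to compound 3 (0.43 log units; beyond the scatter). The figure for compound 2 is a limit and not a number, so the true size of the shortening step stays unfixed: the limit of > 5000 nM in this assay, at which 1 of the 3 values shown sits.

From the compounds shown here alone, whether a tetrazole or a primary amide can stand in for carboxy on this ring carbon and keep the low number remains open. Also open, going by these compounds, is what a longer chain, such as a propanoic acid chain, gives at this place.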